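Swapping 4-Bromophenyl for 3-Carbamoylphenyl: A Cytotoxicity Estimate

A few compounds are considered here, and "the series" means these few. Any claim that something is new, unique, unknown or untested is made for them only; others in the source may bear on it.

In an ADME assay on L6 cells (Rattus norvegicus) for cytotoxicity, read by resazurin assay, with a stated time of 72 h (on this read-out higher numbers stand for weaker inhibition and lower numbers for stronger inhibition), compound 1 `OC(c1ccc(Cl)cc1)(c1cncnc1)c1cccc(F)c1` gives > 100000 nM, which is a limit of the assay and not a number. Compound 2 `OC(c1ccc(Cl)cc1)(c1ccc(Br)cc1)c1cccnc1` gives 57000 nM, and compound 3 `OC(c1ccc(Br)cc1)(c1ccc(C(F)(F)F)cc1)c1cccnc1` gives 54700 nM. These two numbers lie within the scatter of each other, so compound 3 stands level with compound 2.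

Compound 4 `NC(=O)c1cccc(C(O)(c2ccc(C(F)(F)F)cc2)c2cccnc2)c1` has not yet been measured. The structural change that leads to it is 3-carbamoylphenyl in place of 4-bromophenyl on a saturated chain carbon bound to two aromatic carbons and an oxygen on a saturated carbon: 3-carbamoylphenyl enters where 4-bromophenyl leaves, on a saturated chain carbon bound to two aromatic carbons and an oxygen on a saturated carbon.

Going by the values given here, no measured step makes this same exchange. Among the compounds with values here, the only guide among the measured numbers is a 1.0-fold lower number from compound 2 to compound 3 (0.02 log units; within the scatter), which came from trifluoromethyl in place of chloro on an aromatic carbon. That step involved a different group, so it bears only loosely on the new change, and the estimate stays wide. No change beyond the scatter is expected in this assay, and the estimated step is a 1.3-fold higher number from compound 3 to compound 4 (0.11 log units; within the scatter). For compound 4 the expected value is 70000 nM, with an estimated range from 25000 nM to 150000 nM.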

Compound 4, half-maximal inhibitory concentration: > 100000 nM
Compound 4 gave a limit, no number; the forecaster's own chance of this, stated with the estimate: 40%; middle value at least 1.4-fold (0.15 log units) away from the limit.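

In this assay, going by these compounds alone, this is the first measured change on the saturated chain carbon bound to two aromatic carbons and an oxygen, and it reads as an at least 1.8-fold higher number from compound 3 to compound 4 (0.26 log units; that floor lies within the scatter). Compound 4 gives > 100000 nM, which is a limit of the assay and not a number. The exchange of 4-bromophenyl for 3-carbamoylphenyl therefore brings no stronger inhibition of these cells, and the added carbamoyl group is tolerated at this place without any measurable cytotoxicity appearing within the range of the assay, a range whose upper end now caps part of the series: the limit of > 100000 nM in this assay, at which 2 of the 4 values shown sit.

The true size of this step stays unknown, since only its floor can be read and that floor lies within the scatter, so the compounds shown cannot tell whether the exchange truly weakens inhibition or merely leaves it unchanged. They also leave open whether a 3-aminophenyl or a 3-carboxyphenyl group, entering at the same place, would stay at this limit or give a measurable number.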